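A few compounds are considered here, and "the series" means these few. Any claim that something is new, unique, unknown or untested is made for them only; others in the source may bear on it.

In a functional assay on CCRF-CEM cells (Homo sapiens) for cytotoxicity, with a stated time of 72 h (a lower number here means a stronger inhibitor, a higher number a weaker inhibitor), the measured compounds read:

Compound 1 `CCOC(=O)/C=C/C=C/c1ccc[nH]1`: > 10000 nM (a limit)
Compound 2 `CCOC(=O)/C=C/C=C/C=C/C=C/c1ccc[nH]1`: 1340 nM
Compound 3 `CCOC(=O)/C=C/C=C/C=C/C=C/C=C/c1ccc[nH]1`: 450 nM

Only two of these three results are actual numbers. Of those two, compound 2 has the higher at 1340 nM, while compound 3 gives 450 nM, a gap beyond the usual scatter. This makes compound 3 the nearest neighbour of compound 2 on the scale. Compound 1 is reported only as a limit, > 10000 nM.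

The next compound to be tested, compound 4 `CCOC(=O)/C=C/C=C/C=C/C=C/c1cccn1C`, keeps the chain of compound 2 and carries methyl in place of hydrogen on an aromatic nitrogen. Put another way, 1H-pyrrol-2-yl becomes 1-methyl-1H-pyrrol-2-yl. Among the compounds with values here, no measured pair in this set carries this change, so the expectation starts from compound 2 at 1340 nM and remains loose. A modest move toward a higher number in this assay is expected, and the result may well stay within the scatter. The expected step is a 1.5-fold higher number from compound 2 to compound 4 (0.17 log units; within the scatter). For compound 4 the estimated value is 2000 nM, with an expected range of 600 nM to 7000 nM.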

Compound 4, half-maximal inhibitory concentration: > 10000 nM
Compound 4: a limit, no number; the forecaster's own chance of this, stated with the estimate: 15%; at least 5.0-fold (0.69 log units) between middle value and limit.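

In this assay, methyl in place of hydrogen on the aromatic nitrogen gives an at least 7.4-fold higher number from compound 2 to compound 4 (0.87 log units; beyond the scatter), so this position on the five-membered aromatic ring is not indifferent to the change. Compound 1, compound 2 and compound 3 differ from one another only in the chain and say nothing about that nitrogen, whereas this step keeps the chain of compound 2 and alters the ring nitrogen alone. The value of compound 4 is a limit and not a number, so the step has a floor but no known upper end: the limit of > 10000 nM in this assay, at which 2 of the 4 values shown sit.

The compounds shown leave open whether this step belongs to methyl in particular or would follow any group on that nitrogen, a question that an ethyl or an acetyl group there would address. They also leave open whether the same change would give a comparable step on the chain of compound 3, which carries the lowest measured number in this series, and whether a methyl on a ring carbon would be tolerated where the one on nitrogen is not.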